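Sulfonyl aryl swap on a quinoline series

A few compounds are considered here, and "the series" means these few. Any claim that something is new, unique, unknown or untested is made for them only; others in the source may bear on it.

Measured so far:
compound 1, `CC1CCN(c2c(S(=O)(=O)c3ccc(Cl)cc3)cnc3cc(Cl)ccc23)CC1`, 91%
compound 2, `COc1ccc2ncc(S(=O)(=O)c3cccc(C#N)c3)c(N3CCC(C)CC3)c2c1`, 90%

In an assay on isolated protein for displacement of a labelled ligand from metabotropic glutamate receptor 5 (Homo sapiens), with a stated time of 60 min, tested at 1 uM (on this read-out lower numbers stand for less inhibition and higher numbers for more inhibition at the one concentration tested (going by the name of the read-out)), compound 1 gives 91% and compound 2 gives 90%. The two numbers lie within the usual scatter of each other, so neither compound can be set above the other; compound 2 simply stands at the same high level of inhibition as compound 1.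

Compound 3, `COc1ccc2ncc(S(=O)(=O)c3ccc(OC)c(OC)c3)c(N3CCC(C)CC3)c2c1`, has not yet been measured. Its structure differs from compound 2 in one place: 3,4-dimethoxyphenyl in place of 3-cyanophenyl on a sulfonyl sulfur. Going by the values given here, no step between two measured compounds is available for this kind of change, so the expectation rests only on the high value of compound 2. Because compound 2 gives 90%, the expected step in this assay is a modest fall, a number 10 percentage points lower from compound 2 to compound 3 (within the scatter), possibly within the scatter. Compound 3 is therefore estimated at 80%, within a range from 55% to 95%.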

Compound 3, a percentage reported as inhibition, at one concentration (the size of the read-out at that concentration, not a potency): -3%
Estimate against measurement, compound 3: 83 percentage points above; measured number outside the range, below it.
By their numbers in this assay, from the lowest: compound 3; then compounds 2 and 1 (each within the scatter of the next).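

The aryl group on the sulfonyl sulfur proves decisive in this assay: 3,4-dimethoxyphenyl in place of 3-cyanophenyl gives a number 93 percentage points lower from compound 2 to compound 3 (beyond the scatter) while the rest of the structure stays the same. Compound 1 and compound 2 had shown only high numbers, which gave no sign that inhibition at the one concentration tested could vanish through a single change at this place. Nothing at hand accounts for this loss.

The change removes the nitrile and adds two methoxy groups in one step, so the compounds shown cannot separate the loss of the one from the arrival of the other. As far as these compounds go, it also remains open whether an unsubstituted phenyl, or an aryl group carrying one methoxy group, a fluorine or an amine, would keep inhibition at this sulfonyl sulfur.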